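Five-membered ring swap on the amine nitrogen of compound 3

The compounds below may be only part of what the source reports. "The series", "measured", "known", "first", "only" and "open" are said of these compounds alone.

Compound 1 `NCc1ccc(CN(Cc2nc3ccccc3[nH]2)C2CCCc3cccnc32)c(CN)c1`: 10 nM
Compound 2 `NCc1cc(C(N)=O)ccc1CN(Cc1nc2ccccc2[nH]1)C1CCCc2cccnc21`: 15 nM
Compound 3 `NCc1cscc1N(Cc1nc2ccccc2[nH]1)C1CCCc2cccnc21`: 13 nM

All three were run in a functional assay on CEM-CCRF cells for antagonist activity at C-X-C chemokine receptor type 4 (Homo sapiens), read by calcium flux; a higher number here means a weaker inhibitor, a lower number a stronger inhibitor. Compound 3 gives 13 nM; its gap to compound 2 and its gap to compound 1 both lie within the scatter, so nothing separates the three on this read-out. Among the compounds with values here, the only step between compounds differing in a single place, a 1.5-fold higher number from compound 1 to compound 2 (0.18 log units; within the scatter), also stays within the scatter; it concerns a carbamoyl in place of aminomethyl on an aromatic carbon.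

Compound 4 `NCc1ccoc1CN(Cc1nc2ccccc2[nH]1)C1CCCc2cccnc21` differs from compound 3 in a group of 8 heavy atoms (6 carbon, 1 nitrogen, 1 oxygen; one five-membered aromatic ring with 1 hetero atom) in place of a group of 7 heavy atoms (5 carbon, 1 nitrogen, 1 sulfur; one five-membered aromatic ring with 1 hetero atom), on an amine nitrogen. Within the data shown here, no measured step touches this position on the amine nitrogen, so the step on an aromatic carbon bears on it only indirectly, as the one sign that a small swap has so far left the read-out within the scatter. The incoming and outgoing groups match in donor and acceptor count and differ by a single heavy atom. For compound 4 the expected step is therefore a 1.2-fold higher number from compound 3 to compound 4 (0.06 log units; within the scatter), none beyond the scatter. Compound 4 is expected to give 15 nM, with a range from 6 nM to 40 nM.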

Compound 4, half-maximal inhibitory concentration: 12 nM
Compound 4: the middle estimate sits 1.3-fold (0.10 log units) above what was measured; the measured number falls inside the stated range.
By their numbers in this assay, from the lowest: compounds 1, 4, 3 and 2 (each within the scatter of the next).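

In this assay, the swap on the amine nitrogen of the group of 7 heavy atoms holding sulfur for the group of 8 heavy atoms holding oxygen gives a 1.1-fold lower number from compound 3 to compound 4 (0.03 log units; within the scatter), so this position now has a measured step, and it stays within the scatter. On the saturated chain carbon bound to an amine nitrogen, the group of 7 heavy atoms with its five-membered aromatic ring stands in place of larger groups with a six-membered aromatic ring of carbon only, giving a 1.3-fold lower number from compound 2 to compound 4 (0.10 log units; within the scatter) and a 1.2-fold higher number from compound 1 to compound 4 (0.08 log units; within the scatter), so these swaps of ring size also leave the read-out within the scatter. No measurement at hand speaks to why these swaps leave the read-out where it is.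

Going by these compounds, all four compounds carry an aminomethyl group, so what a hydroxymethyl group or a carboxylic acid in its place would do to the read-out stays open. No step shown lies beyond the scatter, and whether a longer chain between the amine nitrogen and the aromatic ring would produce one also remains open.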